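A few compounds are considered here, and "the series" means these few. Any claim that something is new, unique, unknown or untested is made for them only; others in the source may bear on it.

Compound 1, `Fc1ccc(-c2nc3cnc(Nc4ccccn4)cc3[nH]2)cc1F`, gives 125000 nM in a physicochemical assay for solubility, using the shake flask method, measured as kinetic solubility, with a stated time of 20 h, at pH 2; on this read-out higher numbers stand for higher solubility and lower numbers for lower solubility.
Compound 2, `Fc1ccc(-c2nc3cnc(Nc4cc(C(F)(F)F)ccn4)cc3[nH]2)cc1F`, gives only a limit of this assay, < 5000 nM.
Compound 3, `Fc1ccc(Nc2cc3[nH]c(-c4ccc(F)c(F)c4)nc3cn2)nc1`, gives 42000 nM.

Among the two values that are numbers, compound 3 stands lowest, and compound 1 sits a modest way above it, as shown by a 3.0-fold lower number from compound 1 to compound 3 (0.47 log units; beyond the scatter). Compound 4, `Fc1ccnc(Nc2cc3[nH]c(-c4ccc(F)c(F)c4)nc3cn2)c1`, has not yet been measured in this assay. It differs from compound 3 by 4-fluoropyridin-2-yl in place of 5-fluoropyridin-2-yl on a nitrogen on an aromatic ring; the two compounds hold the same atoms, joined differently.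

The measured steps offer only indirect guidance. Both known changes put a new group where hydrogen stood: a 3.0-fold lower number from compound 1 to compound 3 (0.47 log units; beyond the scatter) was modest, while an at least 25-fold lower number from compound 1 to compound 2 (1.39 log units; beyond the scatter) was large and reached the limit (the limit of < 5000 nM in this assay, at which 1 of the 3 values shown sits). Among the measured compounds shown here, neither step rearranges an existing group as the change to compound 4 does, so no measured step speaks directly to it.

The step from compound 3 to compound 4 is therefore expected to stay within the usual scatter, a 1.1-fold lower number from compound 3 to compound 4 (0.02 log units; within the scatter). Compound 4 is estimated at 40000 nM, with a range from 15000 nM to 100000 nM.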

Compound 4, solubility: 166000 nM
Compound 4: the middle estimate sits 4.2-fold (0.62 log units) below what was measured; the measured number lies above the stated range.
By their numbers in this assay, from the lowest: compound 3; then compounds 1 and 4 (each within the scatter of the next). At a limit, below all of these: compound 2.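

Rearranging the same atoms does not leave the number in place in this assay: 4-fluoropyridin-2-yl in place of 5-fluoropyridin-2-yl on the nitrogen gives a 4.0-fold higher number from compound 3 to compound 4 (0.60 log units; beyond the scatter) and so moves it by more than the scatter. Fluoro in place of hydrogen therefore has no single outcome here: a 1.3-fold higher number from compound 1 to compound 4 (0.12 log units; within the scatter) stays within the scatter, while a 3.0-fold lower number from compound 1 to compound 3 (0.47 log units; beyond the scatter) lies beyond it. Fluoro in place of trifluoromethyl gives an at least 33-fold higher number from compound 2 to compound 4 (1.52 log units; beyond the scatter) and that step starts from a limit: the limit of < 5000 nM in this assay, at which 1 of the 4 values shown sits.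

The compounds shown leave open how a methoxy group, a chloro group or an amine would read in place of the fluoro of compound 4. They also leave open whether the gap between compound 3 and compound 4 would persist at another pH.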